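This account rests on a few compounds, and the source may have more. Where it says the series, first, only, none or still open, it means among the compounds named here.

Measured compounds in a functional assay for inhibition, with Homo sapiens as the target; a higher number here means weaker binding, a lower number tighter binding:
- compound 1 `CSc1ccc(OC(C)(C)C2OCC(C/C=C\CCC(=O)O)C(c3cccnc3)O2)c([N+](=O)[O-])c1`: 4.47 nM
- compound 2 `COc1ccc(OC(C)(C)C2OCC(C/C=C\CCC(=O)O)C(c3cccnc3)O2)cc1`: 302 nM
- compound 3 `COc1ccc(OC(C)(C)C2OCC(C/C=C\CCC(=O)O)C(c3cccnc3)O2)c([N+](=O)[O-])c1`: 6.17 nM

Compound 2 gives the highest number of the three in this assay; the step of a 49-fold lower number from compound 2 to compound 3 (1.69 log units; beyond the scatter) and the step of a 68-fold higher number from compound 1 to compound 2 (1.83 log units; beyond the scatter) both lie beyond the scatter, so compound 2 is the weakest of the measured set. The step of a 1.4-fold higher number from compound 1 to compound 3 (0.14 log units; within the scatter) is within the scatter.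

Compound 4 `CC(C)(Cc1ccccc1)C1OCC(C/C=C\CCC(=O)O)C(c2cccnc2)O1` differs from compound 2 by benzyl in place of 4-methoxyphenoxy on a saturated chain carbon bound to two saturated chain carbons and a saturated ring carbon. Going by the values given here, the measured steps concern only the group on the aromatic carbon of the 4-methoxyphenoxy and the exchange of one aryl group for another on the same oxygen; no measured pair removes the ether oxygen or puts benzyl in its place, so none of them bears directly on this change. The large steps of a 68-fold higher number from compound 1 to compound 2 (1.83 log units; beyond the scatter) and a 49-fold lower number from compound 2 to compound 3 (1.69 log units; beyond the scatter) show that this end of the molecule moves the number strongly, which argues for a wide range rather than a direction. For compound 4 the number is therefore expected to stay near that of compound 2, as a step of a 1.0-fold lower number from compound 2 to compound 4 (0.00 log units; within the scatter), with an estimate of 300 nM and a range from 40 nM to 2500 nM.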

Compound 4, dissociation constant: 513 nM
The estimate for compound 4 lay 1.7-fold (0.23 log units) below the measured number; the range from low to high includes it.
By their numbers in this assay, from the lowest: compounds 1 and 3 (each within the scatter of the next); then compounds 2 and 4 (each within the scatter of the next).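

In this assay the step of a 1.7-fold higher number from compound 2 to compound 4 (0.23 log units; within the scatter) is the only one here that removes the ether oxygen and the methoxy group, and it stays within the scatter. Compounds 2 and 4 therefore cannot be told apart at this position, so this end of the molecule does not respond strongly to every change, unlike the exchange with a 49-fold lower number from compound 2 to compound 3 (1.69 log units; beyond the scatter) on the aromatic ring. No measured evidence accounts for this result.

The oxygen and the methoxy group leave together, so their separate contributions remain unresolved, as does whether a nitro group on the benzyl ring of compound 4 would give a step like that from compound 2 to compound 3. Also open, on these data alone, is how an amine or a longer chain in place of benzyl would read at this carbon.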